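A few compounds are considered here, and "the series" means these few. Any claim that something is new, unique, unknown or untested is made for them only; others in the source may bear on it.

Measured so far in a functional assay on HT-29 cells (Homo sapiens) for cytotoxicity, read by MTT assay, with a stated time of 72 h; a lower number here means a stronger inhibitor, a higher number a weaker inhibitor:
Compound 1 `CN1C/C(=C\c2ccccc2F)C(=O)/C(=C/c2ccccc2F)C1` gives 2200 nM.
Compound 3 `CCN1C/C(=C\c2ccccc2F)C(=O)/C(=C/c2ccccc2F)C1` gives 5200 nM.
Compound 2 `CN1C/C(=C\c2c(F)cc(F)cc2F)C(=O)/C(=C/c2c(F)cc(F)cc2F)C1` gives > 10000 nM, a limit of the assay and not a number.

Compound 1 and compound 3 share the same core and differ in one place only: methyl in place of hydrogen on a saturated chain carbon bound to an amine nitrogen in a ring. In this assay that change made a 2.4-fold higher number from compound 1 to compound 3 (0.37 log units; beyond the scatter), a step that lies beyond the usual scatter but is modest in size. Compound 2 differs from compound 1 in more than one place; the difference between the two cores is not broken down here. Among the measured compounds shown here, for compound 2 there is only a limit, (the limit of > 10000 nM in this assay, at which 1 of the 3 values shown sits), so the series so far tells nothing about how far past that limit compound 2 actually sits.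

Compound 4 `CCN1C/C(=C\c2c(F)cc(F)cc2F)C(=O)/C(=C/c2c(F)cc(F)cc2F)C1` is not yet measured in this assay. It stands to compound 2 as compound 3 stands to compound 1: the same change, (methyl in place of hydrogen on a saturated chain carbon bound to an amine nitrogen in a ring), made in the same place on the core. Because the earlier step came out as a 2.4-fold higher number from compound 1 to compound 3 (0.37 log units; beyond the scatter), the step from compound 2 to compound 4 is expected to be of the same kind and a similar size, a step that the limit leaves unreadable from compound 2 to compound 4, starting from a value that is already a limit. Compound 4 is therefore estimated at 25000 nM, with a likely range from 9000 nM to 70000 nM, and this assay is expected to report a limit again rather than a number.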

Compound 4, half-maximal inhibitory concentration: 2000 nM
For compound 4 the middle estimate is 13-fold (1.10 log units) above the measured one, outside the stated range (below it).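

In this assay, replacing hydrogen with methyl on a saturated chain carbon bound to an amine nitrogen in a ring does not carry over unchanged from one core to the other, and the two steps run in opposite directions: the same change on two cores in this assay, a 2.4-fold higher number (0.37 log units; beyond the scatter) from compound 1 to compound 3 and an at least 5.0-fold lower number (0.69 log units; beyond the scatter) from compound 2 to compound 4, at least 11-fold (1.07 log units) apart, beyond the scatter of two such steps

The new step reads an at least 5.0-fold lower number from compound 2 to compound 4 (0.69 log units; beyond the scatter); it starts from a limit of the assay and not a number, so its direction and minimum size can be read, but its full size cannot. These two pairs show that, within this series, the outcome of the change depends on the core, so the step seen on the core of compound 1 gives no safe forecast for the core of compound 2, but they establish neither a general rule nor which difference between the cores is responsible.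

The compounds shown leave open how a longer chain, such as propyl, in the same place would behave on each of the two cores. They also leave open whether the reversal would hold on further cores, for example one carrying chlorine in place of fluorine, or whether it is confined to the pair of cores seen here.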